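Ring configuration step from compound 3 to compound 4

This account rests on a few compounds, and the source may have more. Where it says the series, first, only, none or still open, it means among the compounds named here.

Values in an ADME assay on Caco-2 cells (Homo sapiens) for permeability, read by LC-MS, in the apical to basolateral direction, with a stated time of 60 min, at pH 6.5 (on this read-out lower numbers stand for lower permeability and higher numbers for higher permeability), follow
Compound 1 `O=C(NCc1cc(Cl)ccc1-n1cnnn1)[C@@H]1C[C@@H]2C[C@@H]2N1C(=O)[C@H](O)CC1CC1` gives 3.6 10^-6 cm/s
Compound 2 `CC(C)(C)OC[C@@H](O)C(=O)N1[C@H](C(=O)NCc2cc(Cl)ccc2-n2cnnn2)C[C@@H]2C[C@@H]21` gives 4.5 10^-6 cm/s
Compound 3 `CC(C)(C)[C@@H](O)C(=O)N1[C@@H]2C[C@@H]2C[C@H]1C(=O)NCc1cc(Cl)ccc1-n1cnnn1` gives 34 10^-6 cm/s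

Compound 3 stands highest of the three numbers, beyond the scatter from both others. For compound 3 against compound 4 `CC(C)(C)[C@@H](O)C(=O)N1[C@H](C(=O)NCc2cc(Cl)ccc2-n2cnnn2)C[C@@H]2C[C@@H]21` the comparison reads the two compounds have the same atoms and bonds and differ only in configuration as drawn: 2 of 4 stereo elements differ; a stereocentre at a saturated ring carbon is drawn R in compound 3 and S in compound 4; a stereocentre at a saturated ring carbon is drawn R in compound 3 and S in compound 4 and no group leaves or enters. For the measured compounds named here, the only measured step is a 1.3-fold higher number from compound 1 to compound 2 (0.10 log units; within the scatter) and it is a side-chain swap that leaves ring configuration untouched. Going by the values given here, no measured step therefore tests this change, and no shift beyond the scatter is expected. The expected step is a 1.7-fold lower number from compound 3 to compound 4 (0.23 log units; within the scatter) with wide uncertainty. Compound 4 is estimated at 20 10^-6 cm/s (expected range 7 10^-6 cm/s to 45 10^-6 cm/s).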

Compound 4, apparent permeability: 16 10^-6 cm/s
The estimate for compound 4 lay 1.3-fold (0.10 log units) above the measured number; measured number inside the range.
By their numbers in this assay, from the lowest: compounds 1 and 2 (each within the scatter of the next); then compound 4; then compound 3.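

In this assay configuration alone moves the number beyond the scatter, with a 2.1-fold lower number from compound 3 to compound 4 (0.33 log units; beyond the scatter) and no group leaving or entering. Side-chain changes now also read beyond the scatter, as tert-butyl in place of (tert-butoxy)methyl gives a 3.6-fold higher number from compound 2 to compound 4 (0.55 log units; beyond the scatter) and tert-butyl in place of cyclopropylmethyl gives a 4.4-fold higher number from compound 1 to compound 4 (0.65 log units; beyond the scatter). The first step is purely stereochemical, because of one plain point: the fact that compounds 3 and 4 differ only in the configuration as drawn.

Still open, as far as these compounds go, is whether the side-chain steps hold in the ring configuration of compound 3, and how an amine or a carboxylic acid in place of the tert-butyl would read.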